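Thioether versus sulfone: a thiophene swap and its expected outcome

A few compounds are considered here, and "the series" means these few. Any claim that something is new, unique, unknown or untested is made for them only; others in the source may bear on it.

The study compares four compounds built around a chalcone-like chain carrying a 4-chlorophenyl ketone. Compound 1 `CSc1ccc(/C=C(/SCc2ccc(C)cc2)C(=O)c2ccc(Cl)cc2)cc1` and compound 2 `Cc1ccc(CS/C(=C/c2ccc(C)s2)C(=O)c2ccc(Cl)cc2)cc1` share a benzyl thioether core, while compound 3 `CSc1ccc(/C=C(\C(=O)c2ccc(Cl)cc2)S(=O)(=O)Cc2ccc(Cl)cc2)cc1` and compound 4 `Cc1ccc(/C=C(\C(=O)c2ccc(Cl)cc2)S(=O)(=O)Cc2ccc(Cl)cc2)s1` carry a benzyl sulfone instead; the difference between the two cores is not broken down here.

In a functional assay on DU-145 cells (Homo sapiens) for inhibition, read by trypan blue exclusion, with a stated time of 96 h (on this read-out lower numbers stand for stronger inhibition of growth and higher numbers for weaker inhibition of growth), compound 1 gives 25000 nM. Compound 2 gives 50000 nM in this assay. The change between them is 5-methylthiophen-2-yl in place of 4-(methylsulfanyl)phenyl on a double-bonded chain carbon bound to a double-bonded chain carbon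
and the measured step is a 2.0-fold higher number from compound 1 to compound 2 (0.30 log units; within the scatter). Compound 3 gives 10000 nM in this assay, which places it lowest of the three measured numbers, beyond the scatter from both compound 1 and compound 2.

Compound 4 is the unmeasured member. It differs from compound 3 by 5-methylthiophen-2-yl in place of 4-(methylsulfanyl)phenyl on a double-bonded chain carbon bound to a double-bonded chain carbon
This is the same change already seen from compound 1 to compound 2, made at the same place on the chain, but now on the sulfone core rather than the thioether core. Among the measured compounds shown here, the only evidence for its effect is that single earlier step, which stayed within the scatter. The step from compound 3 to compound 4 is therefore expected to be a 2.0-fold higher number from compound 3 to compound 4 (0.30 log units; within the scatter), resting on the step of a 2.0-fold higher number from compound 1 to compound 2 (0.30 log units; within the scatter). The expected value for compound 4 in this assay is estimated at 20000 nM, with a range from 8000 nM to 50000 nM.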

Compound 4, concentration for 50% growth inhibition: 1000 nM
Compound 4: the middle estimate sits 20-fold (1.30 log units) above what was measured; measured number below the stated range.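

The exchange of 4-(methylsulfanyl)phenyl for 5-methylthiophen-2-yl does not carry over from one core to the other in this assay: on the sulfone core it gives a 10-fold lower number from compound 3 to compound 4 (1.00 log units; beyond the scatter), so the change that made no clear difference on the thioether core coincides with a clear gain in growth inhibition here. Set side by side, the two steps disagree: the same change on two cores in this assay, a 2.0-fold higher number (0.30 log units; within the scatter) from compound 1 to compound 2 and a 10-fold lower number (1.00 log units; beyond the scatter) from compound 3 to compound 4, 20-fold (1.30 log units) apart, beyond the scatter of two such steps
This shows that, in these two pairs, the outcome of the change depends on the core it is made on, so a step measured on one core is a poor guide to the other; it does not show which feature of the core is responsible or why, and one pair per core gives no general rule for the series.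

The two cores differ both in thioether against sulfone and in the methyl against the chloro on the benzyl group, so the compounds shown leave open which of these two differences goes with the gain seen for compound 4. They also leave open whether an amine or a carboxylic acid at the same place on the chain would follow the step on either core.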